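From 2-methoxyphenyl to phenyl in a three-compound series

A few compounds are considered here, and "the series" means these few. Any claim that something is new, unique, unknown or untested is made for them only; others in the source may bear on it.

compound 1 `O=C1C(=Cc2ccc(Br)cc2)C(=O)N(c2ccc(Cl)cc2)N1c1ccc(Cl)cc1` gives 12300 nM
compound 2 `O=C1C(=Cc2cccc(Cl)c2)C(=O)N(c2ccc(Cl)cc2)N1c1ccc(Cl)cc1` gives 22600 nM
compound 3 `COc1ccccc1C=C1C(=O)N(c2ccc(Cl)cc2)N(c2ccc(Cl)cc2)C1=O` gives 30400 nM

In a functional assay on ECa-109 cells (Homo sapiens) for cytotoxicity, read by MTT assay, with a stated time of 72 h (on this read-out higher numbers stand for weaker inhibition and lower numbers for stronger inhibition), compound 3 gives 30400 nM and stands at the upper end of these numbers. Its nearest neighbour is separated by a 1.3-fold higher number from compound 2 to compound 3 (0.13 log units; within the scatter) and its furthest by a 2.5-fold higher number from compound 1 to compound 3 (0.39 log units; beyond the scatter) on this read-out. Compound 4 `O=C1C(=Cc2ccccc2)C(=O)N(c2ccc(Cl)cc2)N1c1ccc(Cl)cc1` has hydrogen in place of methoxy on an aromatic carbon, ortho to a large group: hydrogen in place of methoxy on an aromatic carbon. Among the measured compounds shown here, no measured step removes a group outright, so only the swaps on this same aryl group bear on it. These are small, with a 1.8-fold higher number from compound 1 to compound 2 (0.26 log units; within the scatter) alongside the two above. Nothing beyond the scatter is therefore expected, and the expected change is a 1.4-fold lower number from compound 3 to compound 4 (0.14 log units; within the scatter). Compound 4 is estimated at 22000 nM, with an expected range from 10000 nM to 48000 nM overall.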

Compound 4, half-maximal inhibitory concentration: 32700 nM
Compound 4: the middle estimate sits 1.5-fold (0.17 log units) below what was measured; the measured number falls inside the stated range.
By their numbers in this assay, from the lowest: compounds 1, 2, 3 and 4 (each within the scatter of the next, the first and the last beyond it).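

In this assay the methoxy group adds nothing that can be told apart from hydrogen, with a 1.1-fold higher number from compound 3 to compound 4 (0.03 log units; within the scatter) and likewise a 1.4-fold higher number from compound 2 to compound 4 (0.16 log units; within the scatter) for chloro in place of hydrogen. Only bromo separates from hydrogen on this aryl group, with a 2.7-fold higher number from compound 1 to compound 4 (0.42 log units; beyond the scatter) as a modest step beyond the scatter. Nothing available explains why bromo alone stands apart. Going by these compounds, it remains open whether an amine or a carboxylic acid on this aryl group would leave the numbers in this range. Also open, on these data alone, is whether bromo would give the same step at another ring position.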